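Adding a hydroxy group to a weak growth inhibitor

This account rests on a few compounds, and the source may have more. Where it says the series, first, only, none or still open, it means among the compounds named here.

Among the measured compounds shown here, in a functional assay on MCF7 cells (Homo sapiens) for inhibition, read by sulforhodamine B assay (on this read-out lower numbers stand for stronger inhibition of growth and higher numbers for weaker inhibition of growth), compound 1 `c1ccc(-c2ccc(-c3ccc(-c4nc5ccccc5[nH]4)cc3)cc2)cc1` gives 39200 nM, which places it at the weak end of the numbers so far. It stands level with compound 2 `FC(F)(F)Oc1ccc(-c2ccc(-c3ccc(-c4nc5ccccc5[nH]4)cc3)cc2)cc1`, at 38400 nM, while compound 3 `COc1ccc(-c2ccc(-c3ccc(-c4nc5ccccc5[nH]4)cc3)cc2)cc1OC` gives 7600 nM. Compound 4 `Oc1cccc2[nH]c(-c3ccc(-c4ccc(-c5ccccc5)cc4)cc3)nc12` has not yet been measured. For the measured compounds named here, its single difference from compound 1 is hydroxy in place of hydrogen on an aromatic carbon.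

Two measured steps offer guidance, though only indirectly, as neither alters the ring that takes the hydroxy. The step of a 1.0-fold lower number from compound 1 to compound 2 (0.01 log units; within the scatter) shows no real change, whereas the step of a 5.2-fold lower number from compound 1 to compound 3 (0.71 log units; beyond the scatter) is modest and goes beyond the scatter. Changes to compound 1 have so far either done nothing or lowered the number modestly, so a small or modest drop seems the likeliest outcome in this assay. The expected step is a 2.2-fold lower number from compound 1 to compound 4 (0.34 log units; beyond the scatter), and no change at all remains possible. For compound 4 the estimated value is 18000 nM, with an expected range of 5000 nM to 45000 nM.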

Compound 4, concentration for 50% growth inhibition: 2200 nM
Estimate against measurement, compound 4: 8.2-fold (0.91 log units) above, and the stated range ends above it.
By their numbers in this assay, from the lowest: compound 4; then compound 3; then compounds 2 and 1 (each within the scatter of the next).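

In this assay hydroxy in place of hydrogen brings an 18-fold lower number from compound 1 to compound 4 (1.25 log units; beyond the scatter) and this step counts as large. Among the compounds shown here, the steps to compound 2 and compound 3 left this ring untouched, so compound 4 gives the first reading at this carbon, ortho to a fused ring, and shows that one added heavy atom here can change the number substantially. No measurement is available to explain why the number fell so far.

Going by these compounds, it remains open whether an amine or a fluorine on the same carbon would lower the number as hydroxy does, or whether hydroxy would have the same effect on another carbon of this ring. It is also unknown whether hydroxy here would lower the number further when combined with the 3,4-dimethoxyphenyl of compound 3.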